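Methyl to sec-butyl on the shared core

This account rests on a few compounds, and the source may have more. Where it says the series, first, only, none or still open, it means among the compounds named here.

Compound 1 `Cc1c(Cc2c(F)cccc2Cl)nc(SCC(=O)c2ccc(F)cc2)[nH]c1=O` is the starting point in an ADME assay on MT4 cells (Homo sapiens) for cytotoxicity, read by MTT assay; on this read-out lower numbers stand for higher toxicity in this test and higher numbers for lower toxicity in this test. There, compound 1 gives > 59000 nM, which is a limit and not a number. Compound 2 `COc1ccc(C(=O)CSc2nc(Cc3c(F)cccc3Cl)c(C)c(=O)[nH]2)cc1` gives > 12000 nM, also only a limit. Going by the values given here, the one measured step, a step that the two limits leave unreadable from compound 1 to compound 2, is a change at another place, methoxy in place of fluoro, so it offers no size to carry over. Compound 3 `CCC(C)c1c(Cc2c(F)cccc2Cl)nc(SCC(=O)c2ccc(F)cc2)[nH]c1=O` has sec-butyl in place of methyl on an aromatic carbon. With no readable step as a guide, no step beyond the scatter is expected in this assay, and no direction can be favoured. The estimated step is an at least 1.1-fold lower number from compound 1 to compound 3 (0.07 log units; that floor lies within the scatter). For compound 3 the estimate is 50000 nM, with an expected range from 12000 nM to 150000 nM.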

Compound 3, half-maximal cytotoxic concentration: > 54000 nM
Compound 3: no number, only a limit; the forecaster's own chance of this, stated with the estimate: 60%; at least 1.0-fold (0.03 log units) between middle value and limit.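

No step can be read between compound 1 and compound 3: in this assay each gives only a limit, not a number. The compounds shown leave open where the half-maximal cytotoxic concentration of any of them actually lies.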